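Removing the Fluorine from Compound 2

The source may hold more compounds than are shown below. What is called first, only, known or untested is meant among the compounds shown, and "the series" means these compounds.

Measured compounds:
compound 1, `N#Cc1cc(-c2nc3ccccc3s2)ccc1N`, 340 nM
compound 2, `C#Cc1cc(-c2nc3ccc(F)cc3s2)ccc1N`, 23 nM

In a functional assay on MDA-MB-468 cells (Homo sapiens) for inhibition, with a stated time of 72 h (on this read-out lower numbers stand for stronger inhibition of growth and higher numbers for weaker inhibition of growth), compound 2 gives the lower of the two numbers. Its nearest neighbour is compound 1, which in this assay gives 340 nM; this gap lies beyond the scatter of repeated measurements. Within the data shown here, compound 1 and compound 2 differ in more than one place, so their two values show only that compound 2 is the stronger inhibitor of the pair.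

Compound 3, `C#Cc1cc(-c2nc3ccccc3s2)ccc1N`, is not yet measured. It is derived from compound 2 by a single change: hydrogen in place of fluoro on an aromatic carbon. The change removes one heavy atom from the shared core and leaves the rest of the structure untouched.

Since no step between measured compounds separates this change from others, its effect is not known from the data shown. Given that it is a small change, the step from compound 2 to compound 3 is expected to be small, a 1.7-fold higher number from compound 2 to compound 3 (0.24 log units; within the scatter), within or only slightly beyond the scatter, with a slight lean toward weaker inhibition. Compound 3 is therefore estimated at 40 nM, between 15 nM and 110 nM.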

Compound 3, concentration for 50% growth inhibition: 15 nM
Beside the measured number, compound 3's estimate is 2.7-fold (0.43 log units) above it; the range from low to high includes it.
By their numbers in this assay, from the lowest: compounds 3 and 2 (each within the scatter of the next); then compound 1.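

In this assay, hydrogen in place of fluoro gives a 1.5-fold lower number from compound 2 to compound 3 (0.19 log units; within the scatter), so on this aromatic carbon, para to a fused ring on one side and meta to a fused ring on the other, the two compounds cannot be told apart. Compound 3 also isolates the other change, which the earlier pair could not do: ethynyl in place of cyano gives a 23-fold lower number from compound 1 to compound 3 (1.36 log units; beyond the scatter), a large step tied to that one group on an aromatic carbon. Nothing at hand gives a reason for either step.

Hydrogen and fluoro are the only two groups shown on the first carbon, so it remains open whether a chlorine, a methoxy group or an amine there would also stay within the scatter of compound 3. Ethynyl and cyano are likewise the only two groups shown on the second carbon, which leaves open how a longer chain such as propynyl, or a simple bromine or hydrogen, would compare with them in this read-out.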